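The source may hold more compounds than are shown below. What is called first, only, known or untested is meant among the compounds shown, and "the series" means these compounds.

Compound 1 `CC(C#CCn1ccnc1)N1CCCC1=O` carries a 1H-imidazol-1-yl on a saturated chain carbon bound to a triple-bonded carbon. In a functional assay on the whole organism for agonist activity, with Mus musculus as the target (on this read-out higher numbers stand for an effect only at larger amounts of compound and lower numbers for an effect already at smaller amounts), compound 1 gives > 100 mg/kg, which is a limit of the assay and not a number, and it is the only such limit among the three values recorded (the limit of > 100 mg/kg in this assay, at which 1 of the 3 values shown sits). Compound 2 `CC(C#CCN(C)C)N1CCCC1=O` is the dimethylamino counterpart of compound 1. In this assay compound 2 gives 6.6 mg/kg. The change dimethylamino in place of 1H-imidazol-1-yl on a saturated chain carbon bound to a triple-bonded carbon therefore brought an at least 15-fold lower number from compound 1 to compound 2 (1.18 log units; beyond the scatter).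

Compound 3 `CN1CCN(CC#CCn2ccnc2)C1=O` is built on a different core; how that core differs from the core of compound 1 is not broken down here. In this assay compound 3 gives 1.4 mg/kg, the lower of the two numbers recorded, with compound 2 the nearer of the other two.

Compound 4 `CN(C)CC#CCN1CCN(C)C1=O` has not yet been measured. It differs from compound 3 by dimethylamino in place of 1H-imidazol-1-yl on a saturated chain carbon bound to a triple-bonded carbon, the same change, at the same place, as that between compound 1 and compound 2. Because that change once gave an at least 15-fold lower number from compound 1 to compound 2 (1.18 log units; beyond the scatter), compound 4 is expected to show a 3.5-fold lower number from compound 3 to compound 4 (0.54 log units; beyond the scatter). On these data alone, the earlier step started from a limit, so its true size is unknown, and a more modest expectation is chosen here. Compound 4 is therefore estimated at 0.4 mg/kg, within a range from 0.1 mg/kg to 1.5 mg/kg.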

Compound 4, dose for half-maximal effect: 0.54 mg/kg
Compound 4: middle estimate off by 1.4-fold (0.13 log units), on the low side; low and high end bracket the measured number.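

On the core of compound 3, dimethylamino in place of 1H-imidazol-1-yl again lowered the number in this assay, with a 2.6-fold lower number from compound 3 to compound 4 (0.41 log units; beyond the scatter), so the direction of the change held on both cores, although two pairs make no rule for any further core. The size of the step did not carry over from one core to the other: the same change on two cores in this assay, an at least 15-fold lower number (1.18 log units; beyond the scatter) from compound 1 to compound 2 and a 2.6-fold lower number (0.41 log units; beyond the scatter) from compound 3 to compound 4, at least 5.8-fold (0.76 log units) apart, beyond the scatter of two such steps. On these data alone, the earlier step starts from compound 1, whose > 100 mg/kg is a limit of the assay and not a number, so the true size of that step, and with it the true gap between the two steps, remains unknown, and the data do not show what sets the size on either core: the limit of > 100 mg/kg in this assay, at which 1 of the 4 values shown sits.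

The compounds shown leave open whether another amine, such as diethylamino or a pyrrolidine bound through its nitrogen, would follow dimethylamino on both cores or lose the direction seen here. They also leave open how a longer chain carrying the same dimethylamino would behave in this assay, and whether the difference in step size would persist on such a chain.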